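The compounds below may be only part of what the source reports. "The series", "measured", "known", "first", "only" and "open" are said of these compounds alone.

Measured compounds in an assay on isolated protein for inhibition of lactase/phlorizin hydrolase (Rattus norvegicus), read by colorimetric assay; a lower number here means a stronger inhibitor, a higher number a weaker inhibitor:
Compound 1, `Cc1ccc(S(=O)(=O)Nc2ccc3c(c2)C(=O)N(Cc2ccc(Cl)cc2)C3=O)cc1`, gives 155000 nM.
Compound 2, `Cc1ccc(S(=O)(=O)Nc2ccc3c(c2)C(=O)N(CCCCBr)C3=O)cc1`, gives only a limit of this assay, > 200000 nM.
Compound 3, `Cc1ccc(S(=O)(=O)Nc2ccc3c(c2)C(=O)N(C)C3=O)cc1`, gives only a limit of this assay, > 200000 nM.

Compound 3 therefore stands at the floor of what this assay can resolve, a position it shares with most of the set (the limit of > 200000 nM in this assay, at which 2 of the 3 values shown sit). Its one readable connection is to compound 1: the step of an at least 1.2-fold higher number from compound 1 to compound 3 (0.11 log units; that floor lies within the scatter), in which hydrogen replaces 4-chlorophenyl on the saturated chain carbon bound to the amide-type nitrogen. The step that the two limits leave unreadable from compound 2 to compound 3 gives nothing further.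

Compound 4, `Cc1ccc(S(=O)(=O)Nc2ccc3c(c2)C(=O)N(CCOc2cccc(O)c2)C3=O)cc1`, differs from compound 3 in one place: (3-hydroxyphenoxy)methyl in place of hydrogen on a saturated chain carbon bound to an amide-type nitrogen in a ring. For the measured compounds named here, no measured pair matches this change exactly. The nearest guide runs the other way along the step from compound 1 to compound 3, where a group carrying an aromatic ring on that chain carbon sat at a measurable value while hydrogen did not. On that slim basis compound 4 is expected to move back into the measurable range by a step of about an at least 1.3-fold lower number from compound 3 to compound 4 (0.12 log units; that floor lies within the scatter), though the chance remains real that this assay again reports only a limit. Compound 4 is estimated at 150000 nM, with a range from 60000 nM to 300000 nM.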

Compound 4, half-maximal inhibitory concentration: 111000 nM
Beside the measured number, compound 4's estimate is 1.4-fold (0.13 log units) above it; the measured number falls inside the stated range.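

In this assay, compound 4 adds a second measured number at this chain position, showing that a readable value there is not confined to the 4-chlorophenyl group. The step of a 1.4-fold lower number from compound 1 to compound 4 (0.15 log units; within the scatter) leaves (3-hydroxyphenoxy)methyl and 4-chlorophenyl indistinguishable in this assay, even though the two groups differ in their atoms and in the link to their aromatic rings. The steps of an at least 1.8-fold lower number from compound 3 to compound 4 (0.25 log units; that floor lies within the scatter) and an at least 1.8-fold lower number from compound 2 to compound 4 (0.25 log units; that floor lies within the scatter) each have a floor that lies within the scatter, which means that neither establishes a real gain from the new group, and the set remains close to the edge of what the assay can read: the limit of > 200000 nM in this assay, at which 2 of the 4 values shown sit.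

Whether any group at this position can move the number beyond the scatter remains open, as no readable step shown here does. Also open, on these data alone, is how an amine or a carboxylic acid on the chain would read, or a methoxy group in place of the hydroxyl of the 3-hydroxyphenoxy group.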